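The compounds below may be only part of what the source reports. "The series", "measured", "known", "first", "only" and "open" are said of these compounds alone.

Among the measured compounds shown here, in a functional assay on HCT-116 cells (Homo sapiens) for cytotoxicity, read by MTT assay, with a stated time of 48 h (on this read-out higher numbers stand for weaker inhibition of growth and lower numbers for stronger inhibition of growth), compound 1 (`CC(C)n1c(C(F)(F)F)nc2cc(Cl)c(Cl)cc21`) gives 81900 nM as the highest number of the three measured so far, and compound 2 (`O=[N+]([O-])c1ccccc1Cn1c(C(F)(F)F)nc2cc(Cl)c(Cl)cc21`) gives 5900 nM as the lowest. Compound 3 (`Clc1cc2ncn(C3CCCC3)c2cc1Cl`) gives 37000 nM and so stands second highest, with both other values beyond the scatter from it.

Compound 4 (`CS(=O)(=O)c1nc2cc(Cl)c(Cl)cc2n1C1CCCC1`) is still to be measured in this assay. Its difference from compound 3 is methylsulfonyl in place of hydrogen on an aromatic carbon and consists of methylsulfonyl in place of hydrogen on an aromatic carbon, between two ring nitrogen atoms and next to the ring atom that bears a cyclopentyl group.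

For the measured compounds named here, no measured pair isolates a change at this place. Compound 1 at 81900 nM and compound 2 at 5900 nM both carry trifluoromethyl in place of that hydrogen, yet they fall on opposite sides of compound 3 and also differ from it in a second group, so the direction remains uncertain. A small step toward a lower number is expected, one that stays within the scatter or only just leaves it.

The estimated step is a 1.9-fold lower number from compound 3 to compound 4 (0.27 log units; within the scatter) on this evidence. For compound 4 the estimated value is 20000 nM with 6000 nM to 65000 nM as the expected range.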

Compound 4, concentration for 50% growth inhibition: 600 nM
For compound 4 the middle estimate is 33-fold (1.52 log units) above the measured one, outside the stated range (below it).
By their numbers in this assay, from the lowest: compound 4; then compound 2; then compound 3; then compound 1.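

The aromatic carbon between two ring nitrogen atoms tolerates substitution and responds strongly to it: in this assay, methylsulfonyl in place of hydrogen brings a 62-fold lower number from compound 3 to compound 4 (1.79 log units; beyond the scatter). Among the compounds shown here, this is the first clean reading of a change at this place, since compound 1 and compound 2 carry trifluoromethyl there but also differ from compound 3 in a second group, so neither could give a direction or a size. The step shows that a substituent here, with the cyclopentyl group and the rest of the core unchanged, can move growth inhibition by a large amount, but no measurement shown accounts for its size.

On these data alone, whether the step belongs to methylsulfonyl itself or would also appear with other groups at this carbon, such as an amine, a carboxylic acid or a methylthio group, remains open. Also open is whether methylsulfonyl has the same effect when the cyclopentyl group is replaced, and whether the step reflects activity on these cells alone, given that only this one cell line is shown.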